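The compounds below may be only part of what the source reports. "The series", "measured", "known", "first", "only" and "open" are said of these compounds alone.

Three compounds built on a shared core were tested in a functional assay on SK-BR-3 cells (Homo sapiens) for inhibition, read by MTT assay, with a stated time of 2 days, tested at 10 uM; on this read-out higher numbers stand for more inhibition of growth at the one concentration tested and lower numbers for less inhibition of growth. Compound 1 `CNC(=O)c1cc(Oc2ccc3nc(NC(=O)Nc4ccc(N5CCN(C)CC5)cc4)sc3c2)ccn1` gives 30.5%, compound 2 `CNC(=O)c1cc(Oc2ccc3nc(NC(=O)Nc4ccc(Cl)cc4)sc3c2)ccn1` gives 50.8%, and compound 3 `CNC(=O)c1cc(Oc2ccc3nc(NC(=O)c4cc(Cl)cc(Cl)c4)sc3c2)ccn1` gives 9.62%, the lowest of the three, with compound 1 nearest and compound 2 furthest above it. Compound 4 `CNC(=O)c1cc(Oc2ccc3nc(NC(=O)Nc4ccc(Br)cc4)sc3c2)ccn1` has not yet been measured. It differs from compound 3 in one place: (4-bromophenyl)amino in place of 3,5-dichlorophenyl on a carbonyl carbon. Within the data shown here, two measured steps bear on this. The step of a number 20.3 percentage points higher from compound 1 to compound 2 (beyond the scatter) changed only a substituent on the outer ring, whereas a number 41.2 percentage points lower from compound 2 to compound 3 (beyond the scatter) removed an arylamino group from the carbonyl carbon, which is the reverse of the change leading to compound 4. A large rise in this assay is therefore expected. Compound 4 is expected at 48%, between 32% and 62%. That amounts to an expected step of a number 38.4 percentage points higher from compound 3 to compound 4 (beyond the scatter).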

Compound 4, percent growth inhibition at one concentration: 26.7%
Compound 4: the middle estimate sits 21.3 percentage points above what was measured; measured number outside the range, below it.
By their numbers in this assay, from the lowest: compound 3; then compounds 4 and 1 (each within the scatter of the next); then compound 2.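

In this assay, (4-bromophenyl)amino on the carbonyl carbon still outscores 3,5-dichlorophenyl (a number 17.1 percentage points higher from compound 3 to compound 4 (beyond the scatter)). Changing only the halogen on the outer ring is enough to move the number, with bromo in place of chloro (a number 24.1 percentage points lower from compound 2 to compound 4 (beyond the scatter)), whereas bromo and 4-methylpiperazin-1-yl cannot be told apart (a number 3.8 percentage points lower from compound 1 to compound 4 (within the scatter)). No evidence is available to explain these differences. Going by these compounds, what fluoro or methoxy in place of bromo would give remains open. So does whether a primary amine on the outer ring would behave like 4-methylpiperazin-1-yl.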